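The source may hold more compounds than are shown below. What is called first, only, known or untested is meant among the compounds shown, and "the series" means these compounds.

Compound 1 `Cc1cc(C(=O)Nc2ccccc2)nn1Cc1cc(Cl)ccc1OCc1ccccc1` gives 39.8 nM in an assay on CHO-K1 cells for displacement of a labelled ligand from prostaglandin E2 receptor EP1 subtype (Homo sapiens); a higher number here means a weaker inhibitor, a lower number a stronger inhibitor. Compound 2 `Cc1cc(C(=O)Nc2ccc(F)cc2)nn1Cc1cc(Cl)ccc1OCc1ccccc1` gives 79.4 nM in this assay, and compound 3 `Cc1cc(C(=O)NCc2ccccn2)nn1Cc1cc(Cl)ccc1OCc1ccccc1` gives 25.1 nM. Compound 3 holds the lowest of the three numbers, though its gap to compound 1, a 1.6-fold lower number from compound 1 to compound 3 (0.20 log units; within the scatter), stays within the scatter, while a 3.2-fold lower number from compound 2 to compound 3 (0.50 log units; beyond the scatter) goes beyond it. Compound 4 `CC(=O)Nc1cc(C)n(Cc2cc(Cl)ccc2OCc2ccccc2)n1` differs from compound 3 in one place: acetamido in place of ((pyridin-2-yl)methyl)carbamoyl on an aromatic carbon. Going by the values given here, the measured steps only exchange the group on the amide nitrogen and leave the numbers close together; none of them removes the whole carbamoyl arm, so no measured step bears directly on this change. Such a large change is expected to weaken binding, a 12-fold higher number from compound 3 to compound 4 (1.08 log units; beyond the scatter), and compound 4 is estimated at 300 nM, with a likely range from 60 nM to 1500 nM.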

Compound 4, half-maximal inhibitory concentration: 316 nM
For compound 4 the middle estimate is 1.1-fold (0.02 log units) below the measured one, and the stated range covers the measured number.
By their numbers in this assay, from the lowest: compounds 3, 1 and 2 (each within the scatter of the next, the first and the last beyond it); then compound 4.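

Swapping the group on the amide nitrogen moved the number only a little, but replacing the whole carbamoyl arm on this aromatic carbon with acetamido weakens binding in this assay from all three starting points (a 13-fold higher number from compound 3 to compound 4 (1.10 log units; beyond the scatter)) (a 7.9-fold higher number from compound 1 to compound 4 (0.90 log units; beyond the scatter)) (a 4.0-fold higher number from compound 2 to compound 4 (0.60 log units; beyond the scatter)). So this position accepts several arms that carry an aromatic ring, and the shorter acetamido, with no ring, falls behind all of them. Nothing here gives a measured reason for this loss.

On these data alone, it remains open whether the ring or the way the amide is attached matters more. A benzamido or a methylcarbamoyl group at this position would help separate the two.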